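Working notes on the step from compound 2 to compound 4

The source may hold more compounds than are shown below. What is called first, only, known or untested is meant among the compounds shown, and "the series" means these compounds.

Measured compounds in a toxicity assay on HeLa cells (Homo sapiens) for cytotoxicity, read by MTT assay, with a stated time of 24 h; a higher number here means a weaker inhibitor, a lower number a stronger inhibitor:
- compound 1 `CCOC(=O)N1CCN(C(=S)SCC(O)Cn2c([N+](=O)[O-])cnc2C)CC1` gives 1610000 nM
- compound 2 `CCN1CCN(C(=S)SCC(O)Cn2c([N+](=O)[O-])cnc2C)CC1`, whose result is only a limit, > 5000000 nM
- compound 3 `Cc1ncc([N+](=O)[O-])n1CC(O)CSC(=S)N1CCN(c2cccc(Cl)c2Cl)CC1` gives 1000000 nM

Compound 2 stands at the assay limit: of the three values, it is the one that sits at the limit of > 5000000 nM in this assay, at which 1 of the 3 values shown sits, so only a bound is known for it. Compound 4 `Cc1ncc([N+](=O)[O-])n1CC(O)CSC(=S)N1CCOCC1` has not been measured in this assay; it differs from compound 2 by morpholin-4-yl in place of 4-ethylpiperazin-1-yl on a thiocarbonyl carbon.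

The measured steps all vary the group on an amine nitrogen in a ring while keeping the ring: an at least 3.1-fold higher number from compound 1 to compound 2 (0.49 log units; beyond the scatter), a 1.6-fold lower number from compound 1 to compound 3 (0.21 log units; within the scatter), and an at least 5.0-fold lower number from compound 2 to compound 3 (0.69 log units; beyond the scatter). None of them exchanges the ring itself, so none bears directly on the step to compound 4. They do show that the two compounds with a number, compound 1 and compound 3, lie within the scatter of each other, and that compound 2 at the limit is the odd one. For compound 4 the expectation is therefore a return toward the level of compounds 1 and 3, with the limit still a real possibility; the estimated step is an at least 2.0-fold lower number from compound 2 to compound 4 (0.30 log units; that floor lies within the scatter). Compound 4 is estimated at 2500000 nM, between 800000 nM and 8000000 nM.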

Compound 4, half-maximal inhibitory concentration: 4520000 nM
Estimate against measurement, compound 4: 1.8-fold (0.26 log units) below; measured number inside the range.
By their numbers in this assay, from the lowest: compounds 3 and 1 (each within the scatter of the next); then compound 4. At a limit, above all of these: compound 2.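

Unlike the earlier steps, which varied the group on the ring nitrogen and kept the ring, this change exchanges the whole ring on the thiocarbonyl carbon, and in this assay it turns a result with no number into one with a number. Compound 2 is a limit and not a number: the limit of > 5000000 nM in this assay, at which 1 of the 4 values shown sits. Morpholin-4-yl in place of 4-ethylpiperazin-1-yl therefore gives only an at least 1.1-fold lower number from compound 2 to compound 4 (0.04 log units; that floor lies within the scatter), so the data show that a compound with a number can be reached at this position with morpholin-4-yl, but not that the ring exchange moves the result beyond the scatter.

From the compounds shown here alone, the true size of this step stays open, since one end of it is a limit, and the data do not separate the effect of the ring oxygen from the loss of the ethyl group. Also open, going by these compounds, is how the series would read with an open-chain amine such as diethylamine on the thiocarbonyl carbon, or with a longer chain in place of ethyl on the ring nitrogen.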